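Pyridin-3-yl for propyl on an alkynyl uridine

This account rests on a few compounds, and the source may have more. Where it says the series, first, only, none or still open, it means among the compounds named here.

Among the measured compounds shown here, compound 1 `CCCC#Cc1cn([C@@H]2O[C@H](CO)[C@@H](O)[C@H](O)[C@H]2O)c(=O)[nH]c1=O` is the only compound here with a measured number: in a functional assay on CCRF-CEM cells (Homo sapiens) for cytotoxicity, with a stated time of 72 h (on this read-out lower numbers stand for stronger inhibition and higher numbers for weaker inhibition), compound 1 gives 123000 nM. Compound 2 `CCCCCc1cc2cn([C@@H]3O[C@H](CO)[C@@H](O)[C@H](O)[C@H]3O)c(=O)nc2o1` reaches only a limit of this assay, > 250000 nM. The step to compound 3 `O=c1[nH]c(=O)n([C@@H]2O[C@H](CO)[C@@H](O)[C@H](O)[C@H]2O)cc1C#Cc1cccnc1` is pyridin-3-yl in place of propyl on a triple-bonded carbon. For the measured compounds named here, no step between measured compounds is known, so its size cannot be read from the data. The step of a 1.2-fold lower number from compound 1 to compound 3 (0.09 log units; within the scatter) is expected to stay within the usual scatter, with no clear direction. Compound 3 is estimated at 100000 nM, between 30000 nM and 250000 nM.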

Compound 3, half-maximal inhibitory concentration: > 250000 nM
Compound 3 gave a limit, no number; the forecaster's own chance of this, stated with the estimate: 30%; middle value at least 2.5-fold (0.39 log units) away from the limit.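

On the triple-bonded carbon, pyridin-3-yl in place of propyl gives an at least 2.0-fold higher number from compound 1 to compound 3 (0.30 log units; that floor lies within the scatter) in this assay. Among the compounds shown here, this is the only step that can be read at this position, and it shows no gain from pyridin-3-yl on this read-out, although its floor does not clear the scatter. From the compounds shown here alone, the true size of the step stays unknown, since the result for compound 3 is only a limit: the limit of > 250000 nM in this assay, at which 2 of the 3 values shown sit. Going by these compounds, it remains open whether an amine or a longer chain on the triple-bonded carbon would give a lower number than compound 1.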